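Aromatic side chain replaces a saturated ring on compound 3

The source may hold more compounds than are shown below. What is called first, only, known or untested is meant among the compounds shown, and "the series" means these compounds.

The measured compounds and their results in a functional assay on the whole organism (B cells) with Mus musculus as the target; a lower number here means a smaller maximal response, a higher number a larger maximal response:
compound 1 `CCCCCCCCCCn1c(=O)n(C2OC(CO)[C@@H](O)[C@H]2O)c2nc(N)nc(O)c21` gives 0%;
compound 2 `N#Cc1cccc(Cn2c(=O)n(C3OC(CO)[C@@H](O)[C@H]3O)c3nc(N)nc(O)c32)c1` gives 16%;
compound 3 `Nc1nc(O)c2c(n1)n(C1OC(CO)[C@@H](O)[C@H]1O)c(=O)n2CCN1CCCCC1` gives 0%.

Compound 3 stands level with compound 1 at the digits reported, and together they are the lowest of the three numbers; only compound 2 lies higher, as the step of a number 16 percentage points lower from compound 2 to compound 3 (beyond the scatter) shows. All three share the same core, and they differ only in the group carried on a saturated chain carbon bound to an aromatic nitrogen.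

Compound 4 `Nc1nc(O)c2c(n1)n(C1OC(CO)[C@@H](O)[C@H]1O)c(=O)n2C/C=C/c1ccccc1` is the next member of the series. The change from compound 3 is 2-phenylethenyl in place of (piperidin-1-yl)methyl on a saturated chain carbon bound to an aromatic nitrogen.

For the measured compounds named here, two measured steps bear on this. When an aromatic group took the place of a plain chain, a number 16 percentage points higher from compound 1 to compound 2 (beyond the scatter); when a saturated ring took the place of a plain chain, no change at the digits printed from compound 1 to compound 3 (within the scatter). Compound 4 brings in an aromatic ring joined through a short chain with one double bond outside aromatic rings, so a modest rise is expected, roughly a number 15 percentage points higher from compound 3 to compound 4 (beyond the scatter).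

Compound 4 is therefore estimated to reach 15% in this assay, with a plausible range from 0% to 35%.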

Compound 4, largest response reached (reported as maximal response), in percent of the reference or control that the assay uses: 73%
The estimate for compound 4 lay 58 percentage points below the measured number; measured number above the stated range.
By their numbers in this assay, from the lowest: compounds 1 and 3 (each within the scatter of the next); then compound 2; then compound 4.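

In this assay, for the compounds shown here, the group on this saturated chain carbon bound to an aromatic nitrogen turns out to control far more of the response than the earlier compounds suggested: the change to 2-phenylethenyl gives a number 73 percentage points higher from compound 3 to compound 4 (beyond the scatter) and, against the plain chain, a number 73 percentage points higher from compound 1 to compound 4 (beyond the scatter) as well. An aromatic ring alone does not capture this, as compound 2 also carries one and yet the change to 2-phenylethenyl gives a number 57 percentage points higher from compound 2 to compound 4 (beyond the scatter) in the same read-out, although this step swaps the nitrile-bearing ring and brings in the double bond in one move, so the two changes cannot be told apart. Nothing available explains why this group gives so much larger a maximal response.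

The compounds shown leave open whether the double bond itself matters, which the saturated 3-phenylpropyl group in the same place would test directly. They also leave open how much the phenyl ring of compound 4 tolerates added groups, such as a methoxy group or an amine.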